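The compounds below may be only part of what the source reports. "The series", "measured", "known", "first", "only" and "open" are said of these compounds alone.

Measured compounds in a functional assay on ASPC1 cells (Homo sapiens) for inhibition, read by MTT assay, with a stated time of 96 h; on this read-out higher numbers stand for weaker inhibition of growth and lower numbers for stronger inhibition of growth:
compound 1 `O=C(NCCCCCCSSCCCCCCNC(=O)c1cc(-c2ccncc2)n[nH]1)c1cc(-c2ccncc2)n[nH]1` gives 25300 nM
compound 2 `C=CCOC(=O)SCCCCCCNC(=O)c1cc(-c2ccncc2)n[nH]1` gives 27500 nM
compound 3 `O=C(OCc1ccccc1)SCCCCCCNC(=O)c1cc(-c2ccncc2)n[nH]1` gives 32300 nM

Compound 3 holds the highest of the three numbers, but the gaps to compound 2 and to compound 1 are both within the scatter, so the three are not separated on this read-out. Among the compounds with values here, the only single-place step so far is a 1.2-fold higher number from compound 2 to compound 3 (0.07 log units; within the scatter), which swaps the group on the saturated chain carbon bound to the oxygen without moving the number beyond the scatter.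

Compound 4 `CCCC(=O)SCCCCCCNC(=O)c1cc(-c2ccncc2)n[nH]1` has not yet been measured. Relative to compound 3 the change is propyl in place of benzyloxy on a carbonyl carbon. This is the same end of the molecule that was varied between compound 2 and compound 3, where the number stayed within the scatter. Within the data shown here, compound 1 differs from compound 3 in more than one place, so it gives no step that bears on this change. Among the measured compounds shown here, with one flat step as the only guide, no shift beyond the scatter is expected, a 1.2-fold lower number from compound 3 to compound 4 (0.06 log units; within the scatter). Compound 4 is therefore estimated at 28000 nM, with a range of 14000 nM to 56000 nM.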

Compound 4, concentration for 50% growth inhibition: 28100 nM
Estimate against measurement, compound 4: 1.0-fold (0.00 log units) below; low and high end bracket the measured number.
By their numbers in this assay, from the lowest: compounds 1, 2, 4 and 3 (each within the scatter of the next).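

In this assay, propyl in place of benzyloxy on a carbonyl carbon whose other neighbour is sulfur gives a 1.1-fold lower number from compound 3 to compound 4 (0.06 log units; within the scatter), and propyl in place of allyloxy at the same carbon gives a 1.0-fold higher number from compound 2 to compound 4 (0.01 log units; within the scatter). The earlier step changed only the group on the oxygen, whereas this change removes the oxygen itself, together with the six-membered aromatic ring and the hydrogen-bond acceptor counted for benzyloxy, and 8 heavy atoms give way to 3, yet the read-out still does not separate the compounds, so this position has now stayed flat across oxygen-linked and all-carbon groups. No measurement shown here accounts for this flatness.

Open at this carbonyl carbon is whether any group moves the number beyond the scatter, for example an amine, a carboxylic acid or a chain longer than propyl. The single-place steps shown all lie at this end of the molecule, so they say nothing about how the number responds to changes in the shared core.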